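Swapping the Methoxyphenyl Pattern on an Inactive Chalcone-Coumarin

A few compounds are considered here, and "the series" means these few. Any claim that something is new, unique, unknown or untested is made for them only; others in the source may bear on it.

Measured compounds:
Compound 1 `COc1ccc(/C=C/C(=O)c2cc3ccc(OCc4cccc(OC)c4)cc3oc2=O)cc1` gives only a limit in a functional assay on MCF7 cells (Homo sapiens) for cytotoxicity, read by MTT assay, with a stated time of 72 h; a higher number here means a weaker inhibitor, a lower number a stronger inhibitor: for compound 1 the reported value is > 100000 nM, which marks the limit of the assay, not a number.
Compound 2 `COC(=O)c1ccc(/C=C/C(=O)c2cc3cc(O)ccc3oc2=O)cc1` gives 1300 nM in this assay.
Compound 3 `COc1cccc(/C=C/C(=O)c2cc3cc(O)ccc3oc2=O)c1OC` gives 8800 nM in this assay.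

Among the compounds with values here, compound 1 stands apart from the other two: it is the one compound of the three that reaches the limit, as summarised in the limit of > 100000 nM in this assay, at which 1 of the 3 values shown sits, while compounds 2 and 3 return measurable numbers. Within the data shown here, compounds 2 and 3 differ from compound 1 at more than one place, so no single step links them to compound 1.

Among the measured compounds shown here, compound 4 `COc1cccc(COc2ccc3cc(C(=O)/C=C/c4cc(OC)ccc4OC)c(=O)oc3c2)c1` is the next compound, and its one difference from compound 1 is 2,5-dimethoxyphenyl in place of 4-methoxyphenyl on a double-bonded chain carbon bound to a double-bonded chain carbon. Since compound 1 already sits at the limit, the expected step from compound 1 to compound 4 is a number no higher from compound 1 to compound 4 (the limit leaves the size open), most likely none beyond the scatter. The estimate for compound 4 in this assay is 100000 nM, with a range from 30000 nM to 300000 nM, and a fair chance that it is again reported only as a limit.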

Compound 4, half-maximal inhibitory concentration: > 100000 nM
Compound 4: no number, only a limit; the forecaster's own chance of this, stated with the estimate: 70%; the middle value lies on the limit itself.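

Compound 1 and compound 4 are each reported only as a limit, so the step between them cannot be read: the limit of > 100000 nM in this assay, at which 2 of the 4 values shown sit.

The compounds shown leave open whether 2,5-dimethoxyphenyl and 4-methoxyphenyl differ at all in this assay, and which single change to compound 1 would give a measurable value.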